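This account rests on a few compounds, and the source may have more. Where it says the series, first, only, none or still open, it means among the compounds named here.

Measured so far:

compound 1 `C[C@H](Nc1nc(N)nc(N)c1C#N)c1cc2ccc(F)cn2c(=O)c1-c1ccccc1` — in an ADME assay on microsomes from liver (Homo sapiens), read by LC-MS, using NADPH, with a stated time of 30 min, tested at 1 uM (on this read-out higher numbers stand for a more stable compound and lower numbers for a less stable compound), compound 1 gives 87%
compound 2 `C[C@H](Nc1nc(N)ncc1C#N)c1cc2ccc(F)cn2c(=O)c1-c1ccccc1` — in this assay compound 2 gives 90%
compound 3 `C[C@H](Nc1ncnc(N)c1C#N)c1cc(=O)n2cc(F)ccc2c1-c1cc(F)cc(F)c1` — in this assay compound 3 gives 91%

All three values sit within the usual scatter of one another, so no ordering among them is drawn.

Compounds 1 and 2 share one core and differ in a single place: amino in place of hydrogen on an aromatic carbon. That change gave a number 3 percentage points lower from compound 2 to compound 1 (within the scatter).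

Compound 3 carries a different core; the difference between the two cores is not broken down here.

Compound 4 `C[C@H](Nc1nc(N)nc(N)c1C#N)c1cc(=O)n2cc(F)ccc2c1-c1cc(F)cc(F)c1` is not yet measured. It arises from compound 3 by the same kind of change: amino in place of hydrogen on an aromatic carbon. The surroundings of the place are not identical, however. In the step from compound 2 to compound 1 the entering amino sits next to the ring nitrogen, ortho to a cyano group and opposite the ring nitrogen; in the step from compound 3 to compound 4 it sits between two ring nitrogen atoms and para to a cyano group.

Within the data shown here, with only one measured instance of this kind of change, the expectation for compound 4 rests on compound 3 giving 91% together with a number 3 percentage points lower from compound 2 to compound 1 (within the scatter), both pointing to a small step. The expected step is a number 2 percentage points lower from compound 3 to compound 4 (within the scatter). Compound 4 is therefore estimated at 89%, within a range from 80% to 96%.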

Compound 4, percent of the compound remaining: 94%
The estimate for compound 4 lay 5 percentage points below the measured number, and the stated range covers the measured number.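

Carried onto the core of compound 3, amino in place of hydrogen on an aromatic carbon gives a number 3 percentage points higher from compound 3 to compound 4 (within the scatter) in this assay. Set beside the step on the other core, the change shows no difference between the two cores that can be told apart: the same change on two cores in this assay, a number 3 percentage points lower (within the scatter) from compound 2 to compound 1 and a number 3 percentage points higher (within the scatter) from compound 3 to compound 4, 6 percentage points apart, within the scatter of two such steps. This shows that in these two pairs the change leaves the percent of compound remaining within the scatter on either core, but it does not show that the two cores respond identically, that a direction of step can be assigned, or that the same would hold on a third core, and the surroundings of the place are not the same in the two pairs.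

The four compounds shown carry only hydrogen or amino on the aromatic carbon between two ring nitrogen atoms, so the behaviour of a larger or differently built group there, such as methylamino, dimethylamino or a methoxy group, remains open. Also open, going by these compounds, is whether the small size of these steps would persist for such groups, or for amino on either core in any read-out other than this assay.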